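This account rests on a few compounds, and the source may have more. Where it says the series, first, only, none or still open, it means among the compounds named here.

Measured in a functional assay on HGC-27 cells (Homo sapiens) for inhibition, read by MTT assay, with a stated time of 72 h; a lower number here means a stronger inhibitor, a higher number a weaker inhibitor:
- Compound 1 `Cc1cc(N2CC[C@@H](C)[C@@H](N(C)c3ncnc4[nH]ccc34)C2)n2nc(SCc3csc4ccc(Cl)cc34)nc2n1`: > 100000 nM, a limit and not a number
- Compound 2 `Cc1cc(N2CC[C@@H](C)[C@@H](N(C)c3ncnc4[nH]ccc34)C2)n2nc(SCC3CCCCC3)nc2n1`: 11500 nM
- Compound 3 `Cc1cc(N2CC[C@@H](C)[C@@H](N(C)c3ncnc4[nH]ccc34)C2)n2nc(SCc3ccc(F)c(Cl)c3)nc2n1`: > 100000 nM, a limit and not a number

Compound 3 sits at the limit of > 100000 nM in this assay, at which 2 of the 3 values shown sit. Its true value is therefore unknown, and any comparison with it has to be made with care.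

Compound 4 `Cc1cc(N2CC[C@@H](C)[C@@H](N(C)c3ncnc4[nH]ccc34)C2)n2nc(SCc3ccc([N+](=O)[O-])cc3)nc2n1` differs from compound 3 in one place, on a saturated chain carbon bound to a sulfur, where 4-nitrophenyl replaces 3-chloro-4-fluorophenyl (4-nitrophenyl in place of 3-chloro-4-fluorophenyl on a saturated chain carbon bound to a sulfur). Both groups are six-membered aromatic rings of carbon only.

The measured steps all change this same place. Putting cyclohexyl in gave an at least 8.6-fold lower number from compound 1 to compound 2 (0.93 log units; beyond the scatter). Taking it out again gave an at least 8.6-fold higher number from compound 2 to compound 3 (0.93 log units; beyond the scatter). Between the two aromatic groups there is a step that the two limits leave unreadable from compound 1 to compound 3, so the data do not show how much one aromatic group differs from another.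

Compound 4 keeps an aromatic ring on that carbon, so it is expected to resemble compound 3 rather than compound 2, in line with an at least 8.6-fold higher number from compound 2 to compound 3 (0.93 log units; beyond the scatter). In this assay, no clear gain is expected, and a result reported only as a limit is quite likely. The expected change is a number no higher from compound 3 to compound 4 (the limit leaves the size open). For compound 4 the estimated value is 100000 nM, with an expected range from 25000 nM to 300000 nM.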

Compound 4, half-maximal inhibitory concentration: 29400 nM
Estimate against measurement, compound 4: 3.4-fold (0.53 log units) above; low and high end bracket the measured number.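

In this assay, compound 4 is the only compound shown with an aromatic group on the saturated chain carbon bound to a sulfur that gives a real number, 29400 nM. An aromatic group at this place therefore does not always end in a limit. Among these compounds, the 4-nitrophenyl group gives an at least 3.4-fold lower number from compound 3 to compound 4 (0.53 log units; beyond the scatter) and an at least 3.4-fold lower number from compound 1 to compound 4 (0.53 log units; beyond the scatter), which shows for the first time that aromatic groups here can differ by more than the scatter. From the compounds shown here alone, both sizes stay open at one end. Each starts from a limit. Cyclohexyl still gives the lower number, with a 2.6-fold higher number from compound 2 to compound 4 (0.41 log units; beyond the scatter), so the gap between this saturated ring and an aromatic ring now has a measured size, and a modest one.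

Going by these compounds, compound 1 and compound 3 both remain limits, so the step between them still cannot be read: the limit of > 100000 nM in this assay, at which 2 of the 4 values shown sit. It also remains open whether the gain in compound 4 comes from the nitro group or from losing the chlorine and fluorine, and how a plain phenyl, a 4-methoxyphenyl or a pyridine ring on that carbon would read.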